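This account rests on a few compounds, and the source may have more. Where it says the series, first, only, none or still open, it means among the compounds named here.

Compound 1, `CC/C(=C(/c1ccc(/C=C/C(=O)O)cc1)c1ccc2[nH]ncc2c1C)c1ccccc1`: 50 nM
Compound 2, `O=C(O)/C=C/c1ccc(/C(=C(\c2ccccn2)C2CCC2)c2ccc3[nH]nc(F)c3c2)cc1`: 22 nM

In a functional assay on MCF7 cells (Homo sapiens) for cytotoxicity, read by CellTiter-Glo, with a stated time of 5 days (on this read-out higher numbers stand for weaker inhibition and lower numbers for stronger inhibition), compound 2 gives 22 nM, the lower of the two numbers recorded so far; compound 1 gives 50 nM, and the gap between the two lies beyond the scatter of repeated measurements. Compound 3, `N#Cc1cc(Cl)cnc1/C(=C(\c1ccc(/C=C/C(=O)O)cc1)c1ccc2[nH]nc(F)c2c1)C1CCC1`, has not yet been measured in this assay. It differs from compound 2 in a single place: 5-chloro-3-cyanopyridin-2-yl in place of pyridin-2-yl on a double-bonded chain carbon bound to a double-bonded chain carbon and a saturated ring carbon. Among the compounds with values here, no pair of measured compounds carries this same change, so the size of its step cannot be read off the two values at hand. Both measured compounds sit close together, and nothing among them indicates that the 5-chloro-3-cyanopyridin-2-yl group should move the number far in either direction. The step is therefore expected to be modest, a 1.5-fold lower number from compound 2 to compound 3 (0.17 log units; within the scatter), and it may well fall within the scatter. For compound 3 the estimate in this assay is 15 nM, with a range from 5 nM to 50 nM.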

Compound 3, half-maximal inhibitory concentration: 1.1 nM
Compound 3: middle estimate off by 14-fold (1.13 log units), on the high side, and the stated range ends above it.
By their numbers in this assay, from the lowest: compound 3; then compound 2; then compound 1.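

Within this assay, the place on a double-bonded chain carbon bound to a double-bonded chain carbon and a saturated ring carbon proves strongly responsive: 5-chloro-3-cyanopyridin-2-yl in place of pyridin-2-yl gives a 20-fold lower number from compound 2 to compound 3 (1.30 log units; beyond the scatter) and is the first single-place change that can be read here, since compound 1 and compound 2 differ in more than one place. The aromatic ring type stays the same in this change, with one hetero atom in a six-membered ring, while the entering group brings a chlorine atom and a nitrile together, so the large step belongs to the two additions taken as a whole. Nothing measured here accounts for the size of this step.

The compounds shown leave open how the step divides between the two additions, and whether 5-chloropyridin-2-yl alone or 3-cyanopyridin-2-yl alone would carry much of it. As far as these compounds go, it also remains open whether a trifluoromethyl group in place of the chlorine, or an amide in place of the nitrile, would keep the number this low.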